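Swapping an Acid Hydroxy for a Carbamoyl Group

A few compounds are considered here, and "the series" means these few. Any claim that something is new, unique, unknown or untested is made for them only; others in the source may bear on it.

The shared core of these compounds carries a side chain ending in a carbonyl group, and the changes made there are followed in a functional assay on HEL cells (Homo sapiens); on this read-out higher numbers stand for lower toxicity in this test and lower numbers for higher toxicity in this test. Compound 1 `Cc1cn([C@@H]2O[C@H](CO[Si](C)(C)C(C)(C)C)[C@@]3(OS(=O)(=O)C=C3NCC(=O)O)[C@H]2O[Si](C)(C)C(C)(C)C)c(=O)n(C)c1=O` gives 136000 nM in this assay. Among the three measured compounds it holds the second highest number: compound 3 `COC(=O)CNC1=CS(=O)(=O)O[C@@]12[C@@H](CO[Si](C)(C)C(C)(C)C)O[C@@H](n1cc(C)c(=O)n(C)c1=O)[C@@H]2O[Si](C)(C)C(C)(C)C` gives 160000 nM, and the change a 1.2-fold higher number from compound 1 to compound 3 (0.07 log units; within the scatter) lies within the scatter, so the two cannot be told apart. Compound 2 `Cc1cn([C@@H]2O[C@H](CO[Si](C)(C)C(C)(C)C)[C@@]3(OS(=O)(=O)C=C3NCC(N)=O)[C@H]2O[Si](C)(C)C(C)(C)C)c(=O)n(C)c1=O` gives 13500 nM, a clearly lower number, and the step of a 10-fold lower number from compound 1 to compound 2 (1.00 log units; beyond the scatter) is the only one beyond the scatter that starts from compound 1.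

Compound 4 `Cc1cn([C@@H]2O[C@H](CO[Si](C)(C)C(C)(C)C)[C@@]3(OS(=O)(=O)C=C3NCC(=O)C(N)=O)[C@H]2O[Si](C)(C)C(C)(C)C)c(=O)n(C)c1=O` has not yet been measured. It differs from compound 1 by carbamoyl in place of hydroxy on a carbonyl carbon. Among the compounds with values here, the entering group is a carbamoyl, so the step most closely related to this change is the one from compound 1 to compound 2, where an amino entered on the carbonyl carbon and the number fell by a modest amount. Compound 4 is therefore expected to give 45000 nM, within a range of 12000 nM to 160000 nM. Within the data shown here, this corresponds to an expected step of a 3.0-fold lower number from compound 1 to compound 4 (0.48 log units; beyond the scatter), downward and somewhat smaller than the one seen for compound 2.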

Compound 4, half-maximal cytotoxic concentration: 14500 nM
The estimate for compound 4 lay 3.1-fold (0.49 log units) above the measured number; the measured number falls inside the stated range.
By their numbers in this assay, from the lowest: compounds 2 and 4 (each within the scatter of the next); then compounds 1 and 3 (each within the scatter of the next).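

In this assay, the drop first seen with an amino group on this carbonyl carbon now appears with a carbamoyl group as well: the exchange for hydroxy gives a 9.4-fold lower number from compound 1 to compound 4 (0.97 log units; beyond the scatter), and the exchange for methoxy gives an 11-fold lower number from compound 3 to compound 4 (1.04 log units; beyond the scatter). Within the data shown here, the amino and carbamoyl ends cannot be told apart, as a 1.1-fold higher number from compound 2 to compound 4 (0.03 log units; within the scatter) shows, so the larger group brings no further change that this test can detect, and across these four compounds the two nitrogen-bearing ends sit low while the hydroxy and methoxy ends sit high, with no compound going against that split. Nothing at hand explains this split or shows what lies behind the lower numbers.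

As far as these compounds go, it remains open whether the nitrogen itself matters, which a dimethylamide or a simple primary amine at the end of the side chain could help to test. Also open, from the compounds shown here alone, is whether the same split holds with a longer chain between the ring nitrogen-bearing amino group and the carbonyl, such as a propanoic acid and its primary amide.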